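Ether substituent variation on the shared core

This account rests on a few compounds, and the source may have more. Where it says the series, first, only, none or still open, it means among the compounds named here.

The three measured compounds differ only in the group on the oxygen on the aromatic ring of the shared core. Compound 1 `COCCOc1ccc2c(c1)CCc1c-2c2c(c3c4ccccc4n(CCO)c13)CNC2=O` gives 40% in an assay on isolated protein for inhibition of mitogen-activated protein kinase kinase kinase 11 (Homo sapiens), tested at 1 uM; a lower number here means less inhibition, a higher number more inhibition at the concentration tested (going by the name of the read-out). Compound 2 `O=C1NCc2c1c1c(c3c2c2ccccc2n3CCO)CCc2cc(OC3CCCC3)ccc2-1` gives 32% in this assay, a change of a number 8 percentage points lower from compound 1 to compound 2 (within the scatter). Compound 3 `N#CCOc1ccc2c(c1)CCc1c-2c2c(c3c4ccccc4n(CCO)c13)CNC2=O` gives 8% in this assay and stands lowest of the three, the steps of a number 32 percentage points lower from compound 1 to compound 3 (beyond the scatter) and a number 24 percentage points lower from compound 2 to compound 3 (beyond the scatter) both falling beyond the scatter.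

Compound 4 `O=C1NCc2c1c1c(c3c2c2ccccc2n3CCO)CCc2cc(OCCOCc3ccccc3)ccc2-1` is not yet measured. It differs from compound 3 by (benzyloxy)methyl in place of cyano on a saturated chain carbon bound to an oxygen on an aromatic ring. The two steps leading into compound 3 bear directly on this change: each replaced an ether-bearing or cycloalkyl substituent with the nitrile, and each lowered the read-out. The step to compound 4 runs the other way, removing the cyano and introducing an ether-containing chain, so an increase beyond the scatter is expected, a number 27 percentage points higher from compound 3 to compound 4 (beyond the scatter), returning toward the region of compounds 1 and 2. Compound 4 is estimated at 35%, with a range from 15% to 55%.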

Compound 4, a percentage reported as inhibition, at one concentration (the size of the read-out at that concentration, not a potency): 0%
The estimate for compound 4 lay 35 percentage points above the measured number; the measured number lies below the stated range.
By their numbers in this assay, from the lowest: compounds 4 and 3 (each within the scatter of the next); then compounds 2 and 1 (each within the scatter of the next).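

In this assay the step to 2-(benzyloxy)ethyl gives a number 8 percentage points lower from compound 3 to compound 4 (within the scatter) and so does not restore the read-out; at this position the nitrile and this longer ether chain cannot be told apart. An ether oxygen in the chain is therefore not enough to hold the read-out, since compound 1 and compound 4 both carry one, yet the terminal phenyl comes with a number 40 percentage points lower from compound 1 to compound 4 (beyond the scatter) in the same assay. The cyclopentyl ether shows a similar gap, with a number 32 percentage points lower from compound 2 to compound 4 (beyond the scatter) on that change, so compounds 1 and 2 stand apart from compounds 3 and 4 at this oxygen.

No measurement shown accounts for these steps. Open, as far as these compounds go, is whether a terminal amine or carboxylic acid on the 2-carbon ether chain would keep the read-out near that of compound 1.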